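The source may report more compounds than this note shows. Statements on the series, on what has been measured and on what is new or still open speak of the compounds shown alone.

Compound 1 `CCSc1cc(C)c(C(=O)N=C(N)N)cc1S(C)(=O)=O`: in a functional assay for inhibition of sodium/hydrogen exchanger (Oryctolagus cuniculus) (a higher number here means a weaker inhibitor, a lower number a stronger inhibitor), compound 1 gives 5.9 nM.
Compound 2 `Cc1cc(Sc2cccc(Cl)c2)c(S(C)(=O)=O)cc1C(=O)N=C(N)N`: in this assay compound 2 gives 37 nM.
Compound 3 `Cc1cc(N2CCC(N)CC2)c(S(C)(=O)=O)cc1C(=O)N=C(N)N`: in this assay compound 3 gives 9.8 nM.

Compound 3 holds the second highest of the three numbers. Its nearest neighbour is compound 1, the step being a 1.7-fold higher number from compound 1 to compound 3 (0.22 log units; within the scatter); the gap to compound 2 is larger, a 3.8-fold lower number from compound 2 to compound 3 (0.58 log units; beyond the scatter). Compound 2 itself sits apart from compound 1 by a 6.3-fold higher number from compound 1 to compound 2 (0.80 log units; beyond the scatter).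

The next compound, compound 4 `Cc1cn(-c2cc(C)c(C(=O)N=C(N)N)cc2S(C)(=O)=O)cn1`, changes the same position that separates compound 3 from the other two: 4-methyl-1H-imidazol-1-yl in place of 4-aminopiperidin-1-yl on an aromatic carbon.

Among the compounds with values here, the steps that bear on this are those at that aromatic carbon. Exchanging ethylsulfanyl for 4-aminopiperidin-1-yl left the number within the scatter, whereas (3-chlorophenyl)sulfanyl gave the modest rise recorded for compound 2. A small aromatic ring with no hydrogen-bond donor is not directly covered by either, so the expectation is a step of a 1.5-fold higher number from compound 3 to compound 4 (0.18 log units; within the scatter), within or only just beyond the scatter, and most likely toward a somewhat higher number. For compound 4 the estimate in this assay is 15 nM, with a range from 5 nM to 50 nM.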

Compound 4, half-maximal inhibitory concentration: 28 nM
The estimate for compound 4 lay 1.9-fold (0.27 log units) below the measured number; low and high end bracket the measured number.
By their numbers in this assay, from the lowest: compounds 1 and 3 (each within the scatter of the next); then compounds 4 and 2 (each within the scatter of the next).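

In this assay the 4-methyl-1H-imidazol-1-yl group gives a 2.9-fold higher number from compound 3 to compound 4 (0.46 log units; beyond the scatter) and a 4.7-fold higher number from compound 1 to compound 4 (0.68 log units; beyond the scatter) on this aromatic carbon ortho to the methylsulfonyl group, so this position does not accept every group of about this size without a change in the number, even though 4-aminopiperidin-1-yl and ethylsulfanyl stay within the scatter of each other. Within the data shown here, the comparison with the arylsulfanyl compound gives a 1.3-fold lower number from compound 2 to compound 4 (0.12 log units; within the scatter) and places the two groups that carry an aromatic ring together, apart from compounds 1 and 3; none of the four compounds goes against this grouping, though it rests on only two compounds on each side. No independent measurement on these compounds bears on what lies behind the step.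

Going by these compounds, it remains open whether the amine of the 4-aminopiperidin-1-yl group matters at all, a question that plain piperidin-1-yl would address directly. On these data alone, likewise, the part played by the methyl group of the new substituent remains open, and unsubstituted imidazol-1-yl on the same shared core would separate it from that of the ring itself.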